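The source may hold more compounds than are shown below. What is called first, only, known or untested is meant among the compounds shown, and "the series" means these compounds.

Three compounds have been measured:
compound 1, `c1ccc(-c2ccc(-c3ccc(-c4nc5ccccc5[nH]4)cc3)cc2)cc1`, giving 41200 nM in a functional assay on A549 cells (Homo sapiens) for inhibition, read by sulforhodamine B assay; on this read-out higher numbers stand for weaker inhibition of growth and lower numbers for stronger inhibition of growth;
compound 2, `COc1ccc(-c2ccc(-c3ccc(-c4nc5ccccc5[nH]4)cc3)cc2)cc1`, giving 38100 nM;
compound 3, `COc1ccc(-c2ccc(-c3ccc(-c4nc5c(O)cccc5[nH]4)cc3)cc2)cc1OC`, giving 1310 nM.

Compound 2 differs from compound 1 by a single change, (methoxy in place of hydrogen on an aromatic carbon). That change gave a 1.1-fold lower number from compound 1 to compound 2 (0.03 log units; within the scatter). Compound 3 rests on a different core, and the difference between the two cores is not broken down here; its value stands well apart from those of compound 1 and compound 2.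

Compound 4, `COc1cc(-c2ccc(-c3ccc(-c4nc5c(O)cccc5[nH]4)cc3)cc2)cc(OC)c1OC`, is not yet measured. It differs from compound 3 by methoxy in place of hydrogen on an aromatic carbon. Among the compounds with values here, this is the same kind of change as the one from compound 1 to compound 2, but the surroundings differ: in compound 2 the entering group sits para to a large group, whereas in compound 4 it sits ortho to a methoxy group, meta to a large group and meta to a methoxy group. For compound 4 a similarly small step is expected, a 1.1-fold lower number from compound 3 to compound 4 (0.04 log units; within the scatter). This rests on compound 2, whose step a 1.1-fold lower number from compound 1 to compound 2 (0.03 log units; within the scatter) stayed within the scatter. Compound 4 is therefore estimated to give about 1200 nM in this assay, most likely between 500 nM and 3000 nM.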

Compound 4, concentration for 50% growth inhibition: < 100 nM
Compound 4 was reported as a limit; the forecaster's own chance of this, stated with the estimate: 3%; at least 12-fold (1.07 log units) between middle value and limit.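

In this assay, the same swap of hydrogen for methoxy gave an at least 13-fold lower number from compound 3 to compound 4 (1.11 log units; beyond the scatter), so a step measured on one core did not predict its size on the other: the same change on two cores in this assay, a 1.1-fold lower number (0.03 log units; within the scatter) from compound 1 to compound 2 and an at least 13-fold lower number (1.11 log units; beyond the scatter) from compound 3 to compound 4, at least 12-fold (1.08 log units) apart, beyond the scatter of two such steps. Compound 4 gave < 100 nM, which is a limit of the assay and not a number, so only a minimum size is known for this step: the limit of < 100 nM in this assay, at which 1 of the 4 values shown sits. The two pairs differ both in the core and in the surroundings of the entering methoxy, and these data do not separate the two or explain the gap.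

From the compounds shown here alone, it remains open how much lies beyond the limit for compound 4. Also open, going by these compounds, is whether an ethoxy group or an amine in place of the entering methoxy would give a similar result.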